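The source may hold more compounds than are shown below. What is called first, only, known or untested is meant among the compounds shown, and "the series" means these compounds.

Working notes on the styryl sulfone series, scored in a functional assay on DU-145 cells (Homo sapiens) for antiproliferative activity, read by trypan blue exclusion; a lower number here means a stronger inhibitor, a higher number a weaker inhibitor.

Compound 1 `COc1ccc(/C=C/S(=O)(=O)Cc2ccc(OC)cc2)cc1` gives only a limit in this assay, > 20000 nM, so no number is available for it. Compound 2 `COc1cc(OC)c(/C=C/S(=O)(=O)Cc2cc(OC)c(OC)c(OC)c2)c(OC)c1` likewise returns only a limit, > 20000 nM. Among the compounds with values here, compound 3 `COc1cc(OC)c(/C=C/S(=O)(=O)Cc2ccc(O)cc2)c(OC)c1` is the single member with a measured number, 7500 nM, and it is the one that carries a free hydroxyl rather than a methoxy on the benzylic ring; it is weak but quantifiable. Compound 1 therefore stands at the limit of > 20000 nM in this assay, at which 2 of the 3 values shown sit, and nothing within the measured set places it any higher or lower than that.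

Compound 4 `COc1ccc(CS(=O)(=O)/C=C/c2ccc(N)cc2)cc1` differs from compound 1 by amino in place of methoxy on an aromatic carbon. Within the data shown here, no step between measured compounds matches this change, so the expectation rests on what compound 2 and compound 3 show: the fully methoxylated compound 2 stays at the limit while compound 3 with its hydroxyl gives a number. On that basis the step from compound 1 to compound 4 is estimated at an at least 2.2-fold lower number from compound 1 to compound 4 (0.34 log units; beyond the scatter), toward stronger inhibition, and likely only modestly beyond the scatter. Compound 4 is therefore expected to give roughly 9000 nM in this assay, within a range of 2500 nM to 30000 nM, with a real chance that it too returns only a limit.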

Compound 4, half-maximal inhibitory concentration: > 20000 nM
Compound 4: no number, only a limit; the forecaster's own chance of this, stated with the estimate: 35%; middle value at least 2.2-fold (0.34 log units) away from the limit.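

Compound 4 returns > 20000 nM in this assay as a limit, not a number. Within the data shown here, compound 1 also stands only at a limit, so no step between compound 1 and compound 4 can be read. As far as these compounds go, whether amino in place of methoxy on an aromatic carbon changes the read-out at all remains open, as does how far either compound lies past the limit.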